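The compounds below may be only part of what the source reports. "The series", "measured", "known", "first", "only" and "open" are said of these compounds alone.

Of the compounds shown here, three built on one shared core have been tested in an ADME assay on MT4 cells (Homo sapiens) for cytotoxicity, read by WST assay; on this read-out higher numbers stand for lower toxicity in this test and lower numbers for higher toxicity in this test. Compound 1 `c1ccc(-c2cnc(Nc3ccc4[nH]ncc4c3)o2)cc1` reaches only a limit there, > 90 uM. Compound 2 `Clc1cccc(-c2cnc(Nc3ccc4[nH]ncc4c3)o2)c1` likewise reaches only a limit, > 100 uM. Compound 3 `Clc1ccc(-c2cnc(Nc3ccc4[nH]ncc4c3)o2)cc1` also stops at a limit, > 90 uM. Accordingly the step from compound 1 to compound 2 is a step that the two limits leave unreadable from compound 1 to compound 2, the step from compound 1 to compound 3 is a step that the two limits leave unreadable from compound 1 to compound 3, and the step from compound 2 to compound 3 is a step that the two limits leave unreadable from compound 2 to compound 3. One of the three values sits at the limit of > 100 uM in this assay, at which 1 of the 3 values shown sits, and two at the limit of > 90 uM in this assay, at which 2 of the 3 values shown sit. Compound 4 `COc1cc(-c2cnc(Nc3ccc4[nH]ncc4c3)o2)ccc1Cl` differs from compound 3 by methoxy in place of hydrogen on an aromatic carbon. Within the data shown here, since none of the measured steps can be read, the step expected is a step that the limit leaves unreadable from compound 3 to compound 4, none beyond the scatter. Compound 4 is therefore estimated to give 100 uM in this assay, between 50 uM and 200 uM.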

Compound 4, half-maximal toxic concentration: 80 uM
Estimate against measurement, compound 4: 1.3-fold (0.10 log units) above; measured number inside the range.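

Unlike the earlier steps, which cannot be read, methoxy in place of hydrogen on an aromatic carbon, ortho to a chloro group, gives a lower bound on a change in this assay: an at least 1.1-fold lower number from compound 3 to compound 4 (0.05 log units; that floor lies within the scatter). Among these compounds, compound 4 thus brings the first value here that is a number and not a limit. The full size of the step stays unknown because compound 3 gives only a limit: the limit of > 90 uM in this assay, at which 2 of the 4 values shown sit.

From the compounds shown here alone, whether an amine, a carboxylic acid or an ethoxy group at this position would give a step beyond the scatter remains open. So does whether methoxy would have the same effect with no chloro group on the ring.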